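The source may report more compounds than this note shows. Statements on the series, on what has been measured and on what is new or still open speak of the compounds shown alone.

Three compounds on one shared core have been run through an ADME assay on microsomes from liver (Homo sapiens); on this read-out higher numbers stand for higher hepatic extraction and lower numbers for lower hepatic extraction. Compound 1 `Cc1c[nH]c(C(=O)Nc2ccccc2-c2nc([C@H]3CCCN(S(C)(=O)=O)C3)cs2)n1` gives 0.83 in this assay. Compound 2 `CS(=O)(=O)N1CCC[C@H](c2csc(-c3ccccc3NC(=O)c3nc(C#N)c[nH]3)n2)C1` gives 0.92 in this assay. Compound 3 `CCS(=O)(=O)N1CCC[C@H](c2csc(-c3ccccc3NC(=O)c3ncc[nH]3)n2)C1` gives 0.95 in this assay. Among the measured compounds shown here, the single step between two measured compounds that differ in one place, cyano in place of methyl on an aromatic carbon, is a number 0.090 higher from compound 1 to compound 2 (within the scatter). Compound 3 stands highest of the three numbers, with compound 2 nearest and within the scatter, and compound 1 furthest, beyond the scatter.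

Compound 4 `CC(=O)N1CCC[C@H](c2csc(-c3ccccc3NC(=O)c3ncc[nH]3)n2)C1` has not yet been measured. It differs from compound 3 by acetyl in place of ethylsulfonyl on an amine nitrogen in a ring. For the measured compounds named here, no measured step touches the amine nitrogen in the ring; the only step known sits on an aromatic carbon and was itself within the scatter, so it offers no guide to this change. With compound 3 at 0.95 and all three numbers gathered in the upper part of the scale, the step into compound 4 is expected to be a number 0.050 lower from compound 3 to compound 4 (within the scatter), which is none beyond the scatter. Compound 4 is accordingly estimated at 0.9 in this assay, with a range from 0.78 to 0.98.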

Compound 4, hepatic extraction ratio: 0.78
For compound 4 the middle estimate is 0.12 above the measured one; measured number inside the range.
By their numbers in this assay, from the lowest: compounds 4, 1, 2 and 3 (each within the scatter of the next, the first and the last beyond it).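

Among the compounds shown here, at the amine nitrogen in the six-membered non-aromatic ring, a single change moves this assay beyond the scatter: acetyl in place of ethylsulfonyl gives a number 0.17 lower from compound 3 to compound 4 (beyond the scatter), whereas the only earlier step, on an aromatic carbon, gave a number 0.090 higher from compound 1 to compound 2 (within the scatter) and stayed within it. This position therefore has a measurable bearing on hepatic extraction in this pair, with the change from ethylsulfonyl, of 5 heavy atoms and 2 hydrogen-bond acceptors, to acetyl, of 3 heavy atoms and 1 hydrogen-bond acceptor, going with the lower number. No measurement available here bears on why this step takes place.

A single pair cannot separate the exchange of sulfonyl for carbonyl from the shortening of the group, and a propanoyl group or a methyl carbamate on the same nitrogen would speak to that question. As far as these compounds go, it also remains open whether acetyl gives a step of similar size on the cores of compound 1 and compound 2, which carry methyl and cyano on the aromatic carbon.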